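The source may report more compounds than this note shows. Statements on the series, on what has been measured and on what is new or still open speak of the compounds shown alone.

Compound 1 `COc1cc(-c2nc3cc(/C=C4\SC(=O)N(CC(=O)N5CCOCC5)C4=O)ccc3[nH]2)cc(OC)c1OC` and compound 2 `COc1cc(OC)c(-c2nc3cc(/C=C4\SC(=O)N(CC(=O)N5CCOCC5)C4=O)ccc3[nH]2)cc1OC` share one core and differ only in one group: 2,4,5-trimethoxyphenyl in place of 3,4,5-trimethoxyphenyl on an aromatic carbon. In a functional assay on HT-1080 cells (Homo sapiens) for inhibition, read by MTT assay, with a stated time of 48 h (a higher number here means a weaker inhibitor, a lower number a stronger inhibitor), compound 1 gives 1680 nM, and compound 2 gives 1120 nM; the step reads a 1.5-fold lower number from compound 1 to compound 2 (0.18 log units; within the scatter), so the two numbers cannot be told apart with confidence. Compound 3 `COc1cc(-c2nc3cc(/C=C4\SC(=O)N(Cc5cccc(C)c5)C4=O)ccc3[nH]2)cc(OC)c1OC` keeps the aryl group of compound 1 but carries a different group on the ring nitrogen: 3-methylphenyl in place of (morpholin-4-yl)carbonyl on a saturated chain carbon bound to an amide-type nitrogen in a ring. In this assay compound 3 gives 4580 nM, and the step reads a 2.7-fold higher number from compound 1 to compound 3 (0.44 log units; beyond the scatter). Compound 4 `COc1cc(OC)c(-c2nc3cc(/C=C4\SC(=O)N(Cc5cccc(C)c5)C4=O)ccc3[nH]2)cc1OC` has not yet been measured. It differs from compound 3 in 2,4,5-trimethoxyphenyl in place of 3,4,5-trimethoxyphenyl on an aromatic carbon. The surroundings of this change match those of the change from compound 1 to compound 2 word for word, so it is the same change made on a second core, and the two cores differ as the change from compound 1 to compound 3 describes. Since the earlier step of a 1.5-fold lower number from compound 1 to compound 2 (0.18 log units; within the scatter) stayed small, the same change is expected to do little on compound 3 as well, with an expected step of a 1.4-fold lower number from compound 3 to compound 4 (0.14 log units; within the scatter). For compound 4 the estimated value in this assay is 3300 nM, expected to fall between 1800 nM and 6500 nM. This expectation rests on a single measured pair, so it is tentative.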

Compound 4, half-maximal inhibitory concentration: 190 nM
For compound 4 the middle estimate is 17-fold (1.24 log units) above the measured one; measured number below the stated range.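

In this assay, the swap to 2,4,5-trimethoxyphenyl that did little on the core of compound 1 has a large effect on the core of compound 3, with a 24-fold lower number from compound 3 to compound 4 (1.38 log units; beyond the scatter), so the size of this change does not carry from one core to the other: the same change on two cores in this assay, a 1.5-fold lower number (0.18 log units; within the scatter) from compound 1 to compound 2 and a 24-fold lower number (1.38 log units; beyond the scatter) from compound 3 to compound 4, 16-fold (1.21 log units) apart, beyond the scatter of two such steps. Seen from the other side of the same set of four compounds, replacing (morpholin-4-yl)carbonyl with 3-methylphenyl gives a 5.9-fold lower number from compound 2 to compound 4 (0.77 log units; beyond the scatter), which runs in the opposite direction to the step it made on the 3,4,5-trimethoxyphenyl compounds: the same change on two cores in this assay, a 2.7-fold higher number (0.44 log units; beyond the scatter) from compound 1 to compound 3 and a 5.9-fold lower number (0.77 log units; beyond the scatter) from compound 2 to compound 4, 16-fold (1.21 log units) apart, beyond the scatter of two such steps. Going by these compounds alone, the two changes therefore do not add up independently in these compounds, but four compounds in this assay show only that the two groups depend on each other here, not why they do or whether the same holds on any other core.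

The compounds shown leave open whether the large step needs the 3-methylphenyl group itself or would also appear with a plain phenyl, a carboxylic acid or a longer alkyl chain in its place. They also leave open how a dimethoxyphenyl or a single methoxyphenyl group would behave on the same aromatic carbon of either core.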